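Furan amide substitution in a chemokine receptor antagonist series

The compounds below may be only part of what the source reports. "The series", "measured", "known", "first", "only" and "open" are said of these compounds alone.

The three measured compounds share one core and differ only in the aryl group on the amide carbonyl. Compound 1 `CCCC(=O)N1CCC(NS(=O)(=O)c2ccc(NC(=O)c3ccc(C)cc3)c3ccccc23)CC1` gives 9.5 nM in an in vitro functional assay on CHO/Galpha16 cells for antagonist activity at C-C chemokine receptor type 8 (Homo sapiens), read by FLIPR; a lower number here means a stronger inhibitor, a higher number a weaker inhibitor. Compound 2 `CCCC(=O)N1CCC(NS(=O)(=O)c2ccc(NC(=O)c3ccc(F)cc3)c3ccccc23)CC1` gives 59.5 nM in this assay, and compound 3 `CCCC(=O)N1CCC(NS(=O)(=O)c2ccc(NC(=O)c3ccoc3)c3ccccc23)CC1` gives 1520 nM. Compound 3 therefore stands at the weak end of the set: the step of a 160-fold higher number from compound 1 to compound 3 (2.20 log units; beyond the scatter) and the step of a 26-fold higher number from compound 2 to compound 3 (1.41 log units; beyond the scatter) both lie far beyond the scatter, while the step of a 6.3-fold higher number from compound 1 to compound 2 (0.80 log units; beyond the scatter) is modest.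

Compound 4 `CCCC(=O)N1CCC(NS(=O)(=O)c2ccc(NC(=O)c3cc(C)oc3C(F)(F)F)c3ccccc23)CC1` is not yet measured. It differs from compound 3 by 5-methyl-2-(trifluoromethyl)furan-3-yl in place of furan-3-yl on a carbonyl carbon. Within the data shown here, no measured step adds substituents to the furan itself, so the nearest guide is indirect: the two aryl amides carrying a substituent, compound 1 and compound 2, both read far lower than compound 3, and the exchange of methyl for fluoro within that pair moved the number only modestly. On that basis he expects compound 4 to read lower than compound 3 in this assay, with the step of a 5.1-fold lower number from compound 3 to compound 4 (0.70 log units; beyond the scatter) as his estimate, though the direction is uncertain. His estimate for compound 4 is 300 nM, within 60 nM to 1500 nM.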

Compound 4, half-maximal inhibitory concentration: 46.9 nM
Compound 4: middle estimate off by 6.4-fold (0.81 log units), on the high side; measured number outside the range, below it.
By their numbers in this assay, from the lowest: compound 1; then compounds 4 and 2 (each within the scatter of the next); then compound 3.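

Substitution on the furan itself recovers much of what the plain furan-3-yl group gave up at this place on the carbonyl carbon: in this assay, 5-methyl-2-(trifluoromethyl)furan-3-yl gives a 32-fold lower number from compound 3 to compound 4 (1.51 log units; beyond the scatter), so a furan here need not read weak. The substituted furan also stands level with the 4-fluorophenyl amide, at a 1.3-fold lower number from compound 2 to compound 4 (0.10 log units; within the scatter), which shows that a five-membered aromatic ring can do as well at this position as that six-membered aryl group. It does not reach the 4-methylphenyl amide, however, as a 4.9-fold higher number from compound 1 to compound 4 (0.69 log units; beyond the scatter) shows, and that amide remains the strongest inhibitor of the four.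

Nothing in the data gives a measured reason for the size of these steps. Which of the two added groups carries the gain from the plain furan stays open, as does how an ethyl group or a chlorine atom on the furan would read at this position.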